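Swapping a methylsulfonyl for a triazole in an adrenergic agonist series

A few compounds are considered here, and "the series" means these few. Any claim that something is new, unique, unknown or untested is made for them only; others in the source may bear on it.

Measured so far:
compound 1 `Clc1ccc2c(c1-c1cn[nH]c1)CCC2c1ncc[nH]1`: 52%
compound 2 `CS(=O)(=O)Cc1cccc2c1CCC2c1ncc[nH]1`: 70%

In a functional assay on CHO cells for agonist activity at Alpha-1A adrenergic receptor (Homo sapiens), read by fluorescence and calcium flux (on this read-out higher numbers stand for larger maximal responses and lower numbers for smaller maximal responses), compound 2 gives the higher of the two numbers obtained so far, and compound 1 sits a gap below it that lies beyond the usual scatter of repeated measurements. Compound 1 and compound 2 differ from each other in more than one place, so their two values cannot be tied to any single replacement.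

Compound 3 `c1cc(Cn2ccnn2)c2c(c1)C(c1ncc[nH]1)CC2` has not yet been tested in this assay. It differs from compound 2 in one place only: 1H-1,2,3-triazol-1-yl in place of methylsulfonyl on a saturated chain carbon bound to an aromatic carbon. For the measured compounds named here, no measured pair of compounds shows what this kind of replacement does, so no step can be read off the data. Both groups are attached at the same place, on a saturated chain carbon bound to an aromatic carbon, and both carry only hydrogen-bond acceptors, so the expectation is a step of no more than the scatter, in no clear direction, but with a wide range of uncertainty.

Compound 3 is therefore expected to give about 65%, somewhere between 40% and 90%. This estimate means an expected step of a number 5 percentage points lower from compound 2 to compound 3 (within the scatter) that stays within the scatter.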

Compound 3, largest response reached (Emax), in percent of the reference or control that the assay uses: 62%
Compound 3: the middle estimate sits 3 percentage points above what was measured; measured number inside the range.
By their numbers in this assay, from the lowest: compounds 1, 3 and 2 (each within the scatter of the next, the first and the last beyond it).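

In this assay, for the compounds shown here, this is the first pair that differs in one place only, so it ties a step to a single replacement, which compound 1 and compound 2 could not do. Putting 1H-1,2,3-triazol-1-yl in place of methylsulfonyl on a saturated chain carbon bound to an aromatic carbon gives a number 8 percentage points lower from compound 2 to compound 3 (within the scatter), so the two compounds cannot be told apart on this read-out even though a group with no ring has given way to a five-membered aromatic ring with 3 hetero atoms. Nothing available explains why these two groups give such similar values.

From the compounds shown here alone, it remains open whether an amine, a carboxylic acid or a longer chain at the same place would also stay within the scatter of compound 2, or whether the maximal response at this position can move further in either direction. Going by these compounds, it is also open whether the same replacement would give a similar step on a core carrying other substituents, such as the core of compound 1.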